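The compounds below may be only part of what the source reports. "The series", "measured", "known", "first", "only" and "open" are said of these compounds alone.

Measured so far:
- compound 1 `O=C1c2ccccc2CN1c1cnc(NCc2c(F)ccc3c2CCO3)n2cnnc12`: 2.7 uL/min
- compound 2 `CNC(=O)c1ccc(-c2cnc(NCc3c(F)ccc4c3CCO4)c3cn[nH]c(=O)c23)c(C)n1`: 3 uL/min

In an ADME assay on cells (Hepatocyte, Homo sapiens) for metabolic stability, read by HPLC, with a stated time of 30 min, tested at 1 uM (on this read-out higher numbers stand for fast clearance and lower numbers for slow clearance), compound 1 gives the lower of the two numbers, with compound 2 within the scatter of it, so the two are not separated. For the measured compounds named here, no step between measured compounds is available. Compound 3 `O=C1CC2(CC2)CN1c1cnc(NCc2c(F)ccc3c2CCO3)n2cnnc12` differs from compound 1 by a group of 8 heavy atoms (6 carbon, 1 nitrogen, 1 oxygen; one three-membered non-aromatic ring of carbon only, one five-membered non-aromatic ring with 1 hetero atom) in place of a group of 10 heavy atoms (8 carbon, 1 nitrogen, 1 oxygen; one five-membered non-aromatic ring with 1 hetero atom, one six-membered aromatic ring of carbon only), on an aromatic carbon. Lacking any measured step of this kind, the expectation is a change of no more than the scatter in this assay, in either direction. Compound 3 is therefore expected to give about 2.5 uL/min (range 1.2 uL/min to 5 uL/min), an expected step of a 1.1-fold lower number from compound 1 to compound 3 (0.03 log units; within the scatter).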

Compound 3, intrinsic clearance in a liver preparation (reported as CLH), per the amount of preparation that the assay uses: 3.5 uL/min
Beside the measured number, compound 3's estimate is 1.4-fold (0.15 log units) below it, and the stated range covers the measured number.
By their numbers in this assay, from the lowest: compounds 1, 2 and 3 (each within the scatter of the next).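

In this assay, for the compounds shown here, the exchange on this aromatic carbon, the first measured step at this position, reads a 1.3-fold higher number from compound 1 to compound 3 (0.11 log units; within the scatter) and does not separate the two compounds. The six-membered aromatic ring of carbon only in the leaving group is therefore not needed here to keep the number in this range, and the group with the three-membered carbon ring serves equally on this read-out. No measurement on hand bears on why the two groups are not separated.

On these data alone, whether an amine or a carboxylic acid at this place would stay within the scatter remains open. A longer alkyl chain there is equally untested in the compounds shown.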